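The compounds below may be only part of what the source reports. "The series", "measured", "known", "first", "only" and "open" are said of these compounds alone.

In an ADME assay on MT4 cells (Homo sapiens) for cytotoxicity, read by MTT assay, with a stated time of 5 days (on this read-out lower numbers stand for higher toxicity in this test and higher numbers for lower toxicity in this test), compound 1 `CCCCCNc1cc(Oc2c(OC)cc3cc(C#N)ccc3c2OC)nc(Nc2ccc(C#N)cc2)n1` gives > 125000 nM, which is a limit and not a number. Compound 2 `COc1cc2cc(C#N)ccc2c(OC)c1Oc1cc(NC(C)C)nc(Nc2ccc(C#N)cc2)n1` gives > 125000 nM, which is also a limit. Among the measured compounds shown here, compound 2 therefore has no exact position, and the limit of > 125000 nM in this assay, at which 2 of the 2 values shown sit, covers every value available so far.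

Compound 3 `CCC(C)Nc1cc(Oc2c(OC)cc3cc(C#N)ccc3c2OC)nc(Nc2ccc(C#N)cc2)n1` differs from compound 2 by methyl in place of hydrogen on a saturated chain carbon, two bonds along the chain from a nitrogen on an aromatic ring. In words, methyl replaces hydrogen on a saturated chain carbon, two bonds along the chain from a nitrogen on an aromatic ring, which turns isopropyl into sec-butyl.

For the measured compounds named here, the only measured step bearing on this change is a step that the two limits leave unreadable from compound 1 to compound 2. It concerns the same substituent on the nitrogen, but its size cannot be read, so it sets no magnitude. Going by the values given here, with the limit of > 125000 nM in this assay, at which 2 of the 2 values shown sit, as the only guide, no shift in either direction is expected in this assay beyond the scatter. The expected result is a number no higher from compound 2 to compound 3 (the limit leaves the size open), with no clear change. For compound 3 the estimated value is 125000 nM, with an estimated range of 60000 nM to 250000 nM, and a further limit is the expected form of the result.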

Compound 3, half-maximal cytotoxic concentration: > 125000 nM
Compound 3: a limit, no number (the forecaster's own chance of this, stated with the estimate: 85%); the middle value lies on the limit itself.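

No step among compound 1, compound 2 and compound 3 can be read in this assay, as each result is a limit and not a number: the limit of > 125000 nM in this assay, at which 3 of the 3 values shown sit.

The compounds shown leave open whether pentyl, isopropyl and sec-butyl on the nitrogen differ at all in cytotoxicity, and where the actual half-maximal cytotoxic concentrations lie.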